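This account rests on a few compounds, and the source may have more. Where it says the series, first, only, none or still open, it means among the compounds named here.

Compound 2, `C/C(C#Cc1ccccc1)=N\N/C(N)=N/S(=O)(=O)c1cc(C)c(Cl)cc1SCc1ccc(C(F)(F)F)cc1`, belongs to a small set of compounds tested in a functional assay on HCT-116 cells (Homo sapiens) for antiproliferative activity, read by MTT assay, with a stated time of 72 h (a higher number here means a weaker inhibitor, a lower number a stronger inhibitor), where compound 2 gives 160000 nM. Among the compounds with values here, the only other measured compound, compound 1, `C/C(C#Cc1ccccc1)=N\N/C(N)=N/S(=O)(=O)c1cc(C)c(Cl)cc1SCc1cccc(C)c1`, gives 160000 nM in this assay. Within the data shown here, the one step so far, no change at the digits printed from compound 1 to compound 2 (within the scatter), exchanges one aromatic group on the saturated chain carbon bound to a sulfur for another without moving the number. Compound 3, `C/C(C#Cc1ccccc1)=N\N/C(N)=N/S(=O)(=O)c1cc(C)c(Cl)cc1SCc1cccc2ccccc12`, continues this series at the same position: naphthalen-1-yl in place of 4-(trifluoromethyl)phenyl on a saturated chain carbon bound to a sulfur. With only that single, flat step to rest on, and both measured values sitting at the same weak level, the expectation is that compound 3 will show no change beyond the scatter, so that no change at the digits printed from compound 2 to compound 3 (within the scatter) is estimated to be small. The estimated value for compound 3 in this assay is 160000 nM, with a range from 60000 nM to 400000 nM.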

Compound 3, half-maximal inhibitory concentration: 105000 nM
Compound 3: middle estimate off by 1.5-fold (0.18 log units), on the high side, and the stated range covers the measured number.
By their numbers in this assay, from the lowest: compounds 3, 1 and 2 (each within the scatter of the next).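

In this assay the switch from 4-(trifluoromethyl)phenyl to naphthalen-1-yl gives a 1.5-fold lower number from compound 2 to compound 3 (0.18 log units; within the scatter) and the comparison with the 3-methylphenyl group gives a 1.5-fold lower number from compound 1 to compound 3 (0.18 log units; within the scatter) so both steps stay within the usual scatter. A group with two six-membered aromatic rings of carbon and no fluorine therefore reads the same as the two single-ring groups, and compounds 1, 2 and 3 all sit at one level at this position on a saturated chain carbon bound to a sulfur. Nothing on hand explains why these exchanges leave the number level.

As far as these compounds go, all three groups here are aromatic rings of carbon, so the effect of an amine or a carboxylic acid at this position remains open. Also open, from the compounds shown here alone, is whether a longer chain between the sulfur and the ring would move the number.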